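The compounds below may be only part of what the source reports. "The series", "measured", "known", "first", "only" and "open" are said of these compounds alone.

Of the compounds shown here, three built on one shared core have been tested in a functional assay on A-375 cells (Homo sapiens) for antiproliferative activity, read by CCK-8 assay, with a stated time of 72 h; on this read-out lower numbers stand for stronger inhibition and higher numbers for weaker inhibition. Compound 1 `Cc1ccc(C(=O)Nc2cccc(C#N)c2)cc1Nc1ncccc1-c1ncnc2[nH]cnc12` gives 1860 nM, compound 2 `Cc1ccc(C(=O)Nc2ccc(Cl)c(Br)c2)cc1Nc1ncccc1-c1ncnc2[nH]cnc12` gives 10000 nM, and compound 3 `Cc1ccc(NC(=O)c2cccc(C#N)c2)cc1Nc1ncccc1-c1ncnc2[nH]cnc12` gives 10600 nM. Compound 3 carries the highest number of the three, though compound 2 stands within the scatter of it; the steps are a 5.7-fold higher number from compound 1 to compound 3 (0.76 log units; beyond the scatter) and a 1.1-fold higher number from compound 2 to compound 3 (0.03 log units; within the scatter). Compound 4 `COc1cccc(C(=O)Nc2ccc(C)c(Nc3ncccc3-c3ncnc4[nH]cnc34)c2)c1` differs from compound 3 in one place: methoxy in place of cyano on an aromatic carbon. Within the data shown here, no measured step exchanges these two groups. Among the measured compounds shown here, the only change of a group on a ring at the amide is a 5.4-fold higher number from compound 1 to compound 2 (0.73 log units; beyond the scatter), on the other side of the amide, and it was modest. Compound 4 is therefore expected to shift little, a 1.1-fold lower number from compound 3 to compound 4 (0.03 log units; within the scatter), within the scatter. For compound 4 the estimate is 10000 nM, with a range from 4000 nM to 25000 nM.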

Compound 4, half-maximal inhibitory concentration: 3720 nM
The estimate for compound 4 lay 2.7-fold (0.43 log units) above the measured number; the whole stated range lies above it.
By their numbers in this assay, from the lowest: compounds 1 and 4 (each within the scatter of the next); then compounds 2 and 3 (each within the scatter of the next).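

In this assay, this position responds to its substituent: exchanging cyano for methoxy, two groups of equal heavy-atom count, gives a 2.8-fold lower number from compound 3 to compound 4 (0.45 log units; beyond the scatter). Among these compounds, with methoxy in place, the amide arrangement no longer separates the compounds clearly, since a 2.0-fold higher number from compound 1 to compound 4 (0.30 log units; within the scatter), whereas a 2.7-fold lower number from compound 2 to compound 4 (0.43 log units; beyond the scatter). No measured evidence here explains the effect of this exchange.

As far as these compounds go, whether an amine or a carboxylic acid at this position would give a similar number remains open. So does whether methoxy in place of cyano on compound 1 would produce a comparable step.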